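Replacing the aryl group of compound 2

The source may hold more compounds than are shown below. What is called first, only, known or untested is meant among the compounds shown, and "the series" means these compounds.

Measured so far in a functional assay on HL-60 cells (Homo sapiens) for antiproliferative activity, read by MTT assay, with a stated time of 72 h; a lower number here means a stronger inhibitor, a higher number a weaker inhibitor:
Compound 1 `Cc1cc(C)cc(OCCCON2C(N)=NC(N)=NC23CCOCC3)c1`: 720 nM
Compound 2 `NC1=NC2(CCOCC2)N(OCCCOc2ccc(Cl)cc2Cl)C(N)=N1`: 330 nM

Compound 2, at 330 nM, holds the lower of the two numbers in this assay, and its gap to compound 1 lies beyond the scatter. The next compound, compound 3 `NC1=NC2(CCOCC2)N(OCCCOc2cccc(Br)c2)C(N)=N1`, keeps the shared core and the chain and differs from compound 2 at one place: 3-bromophenyl in place of 2,4-dichlorophenyl on an oxygen on a saturated carbon. In words, this puts 3-bromophenyl in place of 2,4-dichlorophenyl on an oxygen on a saturated carbon.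

Within the data shown here, only one measured step bears on this change, a 2.2-fold lower number from compound 1 to compound 2 (0.34 log units; beyond the scatter), a modest step at the same place. Among the measured compounds shown here, no measured compound carries a bromine, so this single step is a thin guide. A step no larger than that one is expected, tilted toward a higher number since compound 2 holds the lower value of the pair, and it may stay within the scatter. The estimated change is a 1.5-fold higher number from compound 2 to compound 3 (0.16 log units; within the scatter). For compound 3 the expected value is 480 nM, with an estimated range of 170 nM to 1300 nM.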

Compound 3, half-maximal inhibitory concentration: 560 nM
Compound 3: middle estimate off by 1.2-fold (0.07 log units), on the low side; low and high end bracket the measured number.
By their numbers in this assay, from the lowest: compounds 2, 3 and 1 (each within the scatter of the next, the first and the last beyond it).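

In this assay the exchange on the oxygen-bearing chain gives a 1.7-fold higher number from compound 2 to compound 3 (0.23 log units; within the scatter) and the comparison with the dimethyl compound gives a 1.3-fold lower number from compound 1 to compound 3 (0.11 log units; within the scatter) and both of these lie within the scatter. Compound 1 and compound 2 had stood apart by more than the scatter, yet compound 3, with its 3-bromophenyl group, cannot be separated from either of them, so the earlier gap does not extend into a clean ranking of the three aryl groups. This position therefore accepts a single bromine in place of two chlorine atoms or two methyl groups without a change that can be read beyond the scatter, and nothing given here explains the numbers.

With only three substituted phenyl groups in view, all carrying halogen or methyl substituents, these compounds leave open how an amine or a carboxylic acid on the aryl ring would read in this assay and whether a step beyond the scatter can be reached at this position. They also leave open what a longer chain would do to the number, since the chain is the same in all three compounds.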